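Thiocarbamate amine variation on a chlorochromone core

This account rests on a few compounds, and the source may have more. Where it says the series, first, only, none or still open, it means among the compounds named here.

Measured so far:
compound 1 `O=c1cc(CSC(=S)N2CCCCC2)oc2cc(Cl)ccc12` — in a functional assay on HeLa cells (Homo sapiens) for antiproliferative activity, read by MTT assay, with a stated time of 72 h (on this read-out lower numbers stand for stronger inhibition and higher numbers for weaker inhibition), compound 1 shows only the limit > 25000 nM.
compound 2 `O=c1cc(CSC(=S)N2CCCC2)oc2cc(Cl)ccc12` — in this assay compound 2 shows only the limit > 40000 nM.
compound 3 `CCN(CC)C(=S)SCc1cc(=O)c2ccc(Cl)cc2o1` — in this assay compound 3 gives 8700 nM.

Compound 3 is the only one of the three that yields a number; the other two stand at a limit, so it is the reference point for the series. Compound 4 `O=c1cc(CSC(=S)N2CCOCC2)oc2cc(Cl)ccc12` is next to be measured in this assay. It differs from compound 3 by morpholin-4-yl in place of diethylamino on a thiocarbonyl carbon: the open chain amine is replaced by a saturated ring.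

Among the compounds with values here, two measured steps bear on this kind of change, both running from a ring amine to diethylamino: an at least 2.8-fold lower number from compound 1 to compound 3 (0.45 log units; beyond the scatter) and an at least 4.5-fold lower number from compound 2 to compound 3 (0.66 log units; beyond the scatter). Read in reverse, they point to a higher number when a ring enters on the thiocarbonyl carbon, with a fair chance that only a limit is returned. The two ring compounds themselves cannot be ordered, since a step that the two limits leave unreadable from compound 1 to compound 2.

Compound 4 is therefore expected at 30000 nM, within 10000 nM to 90000 nM. The step of a 3.4-fold higher number from compound 3 to compound 4 (0.54 log units; beyond the scatter) is expected to run towards weaker inhibition.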

Compound 4, half-maximal inhibitory concentration: 33300 nM
For compound 4 the middle estimate is 1.1-fold (0.05 log units) below the measured one; low and high end bracket the measured number.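

Compound 4 is the only ring amine on the thiocarbonyl carbon shown that returns a number in this assay, so the step away from diethylamino now has a size: a 3.8-fold higher number from compound 3 to compound 4 (0.58 log units; beyond the scatter). Against pyrrolidin-1-yl there is only a floor, an at least 1.2-fold lower number from compound 2 to compound 4 (0.07 log units; that floor lies within the scatter), so morpholin-4-yl and pyrrolidin-1-yl cannot be ordered. The step between compound 1 and compound 4 cannot be read, as compound 1 stands only at a limit: the limit of > 25000 nM in this assay, at which 1 of the 4 values shown sits.

Diethylamino is the only open chain amine here, so whether dimethylamino or dipropylamino would also give a lower number than the ring amines remains open. As far as these compounds go, how a piperazin-1-yl ring would compare with morpholin-4-yl also remains open.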